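The source may report more compounds than this note shows. Statements on the series, on what has been measured and on what is new or still open speak of the compounds shown alone.

Working notes on the series. In a functional assay on HCT-116 cells (Homo sapiens) for antiproliferative activity, read by MTT assay, with a stated time of 72 h (on this read-out lower numbers stand for stronger inhibition and higher numbers for weaker inhibition), compound 1 (`O=S1(=O)C=Cc2ccc(Nc3ccc(C(F)(F)F)cc3)cc21`) gives 1340 nM and compound 2 (`COc1ccc(Nc2ccc3c(c2)S(=O)(=O)C=C3)cc1`) gives 1170 nM, with a 1.1-fold lower number from compound 1 to compound 2 (0.06 log units; within the scatter). Compound 3 (`O=S1(=O)C=Cc2ccc(Nc3ccc(Cl)cc3)cc21`) gives 4440 nM, the highest number of the three and the weakest result so far.

The next structure is compound 4 (`O=S1(=O)C=Cc2ccc(Nc3ccc(Cl)c(Cl)c3)cc21`), with the change chloro in place of hydrogen on an aromatic carbon, ortho to a chloro group. Going by the values given here, no measured step adds a second group in this way. The closest evidence comes from replacing one group with another, which gave a 3.3-fold higher number from compound 1 to compound 3 (0.52 log units; beyond the scatter) and a 3.8-fold higher number from compound 2 to compound 3 (0.58 log units; beyond the scatter). Both steps are modest, so a modest change is the working expectation here too, leaning towards a lower number, although the data do not settle the direction. The expected change is a 1.8-fold lower number from compound 3 to compound 4 (0.25 log units; within the scatter), and this remains an estimate. For compound 4, the estimated value in this assay is 2500 nM, with an expected range of 900 nM to 6000 nM.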

Compound 4, half-maximal inhibitory concentration: 2470 nM
Compound 4: the middle estimate sits 1.0-fold (0.01 log units) above what was measured; the measured number falls inside the stated range.
By their numbers in this assay, from the lowest: compounds 2, 1, 4 and 3 (each within the scatter of the next, the first and the last beyond it).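

In this assay, going by these compounds alone, this is the first step that adds a group instead of replacing one: chloro in place of hydrogen, ortho to a chloro group and meta to a large group, gives a 1.8-fold lower number from compound 3 to compound 4 (0.25 log units; within the scatter), so the step cannot be told apart from repeat scatter. On these compounds, then, this position carries a second chloro with no readable shift in the antiproliferative read-out, whereas the replacements at the existing chloro site in compound 3 gave steps beyond the scatter. Nothing measured on these compounds offers an explanation for this result.

From the compounds shown here alone, whether a different group at this position, such as an amine, a carboxylic acid or a longer chain, would give a step beyond the scatter stays open. Also open, going by these compounds, is how a chloro group here behaves when the neighbouring chloro group is replaced by methoxy or trifluoromethyl.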